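The source may hold more compounds than are shown below. What is called first, only, known or untested is meant among the compounds shown, and "the series" means these compounds.

Measured in an ADME assay for permeability, using PAMPA, at pH 7.4; on this read-out higher numbers stand for higher permeability and lower numbers for lower permeability:
compound 1 `O=C(Nc1cc(-c2nc3ccccc3o2)ccc1F)c1cc([N+](=O)[O-])ccc1Cl` gives 214 10^-6 cm/s
compound 2 `O=C(Nc1cc(-c2nc3ccccc3s2)ccc1F)c1cc([N+](=O)[O-])ccc1Cl` gives 191 10^-6 cm/s

Only these two numbers exist, and they lie within the scatter of each other (a 1.1-fold lower number from compound 1 to compound 2 (0.05 log units; within the scatter)), so compound 1 cannot be set apart from compound 2 on this assay. Compound 3 `O=C(Nc1cccc(-c2nc3ccccc3o2)c1)c1cc([N+](=O)[O-])ccc1Cl` differs from compound 1 as follows: hydrogen in place of fluoro on an aromatic carbon. Among the compounds with values here, no measured step touches this position; the single step available, a 1.1-fold lower number from compound 1 to compound 2 (0.05 log units; within the scatter), concerns a different part of the core and stayed within the scatter. No step beyond the scatter is therefore expected, and the estimate is a 1.1-fold lower number from compound 1 to compound 3 (0.04 log units; within the scatter). Compound 3 is expected to give 195 10^-6 cm/s, within 110 10^-6 cm/s to 320 10^-6 cm/s.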

Compound 3, apparent permeability: 45 10^-6 cm/s
The estimate for compound 3 lay 4.3-fold (0.64 log units) above the measured number; measured number outside the range, below it.
By their numbers in this assay, from the lowest: compound 3; then compounds 2 and 1 (each within the scatter of the next).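

On this assay this position is sensitive: hydrogen in place of fluoro, on the aromatic carbon para to the 1,3-benzoxazol-2-yl group, gives a 4.8-fold lower number from compound 1 to compound 3 (0.68 log units; beyond the scatter) and so moves the number beyond the scatter. Within the data shown here, the only earlier step, a 1.1-fold lower number from compound 1 to compound 2 (0.05 log units; within the scatter), changed a different part of the core and did not do so. No supporting data explain the drop.

Still open, as far as these compounds go, is whether chloro, methoxy or an amine at this position would stay with compound 1 or with compound 3. Also open, from the compounds shown here alone, is whether the same change on compound 2 gives a similar step.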